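This account rests on a few compounds, and the source may have more. Where it says the series, first, only, none or still open, it means among the compounds named here.

Of the compounds shown here, three of the shared core have been measured in a functional assay on the whole organism for inhibition, with Homo sapiens as the target; on this read-out higher numbers stand for weaker inhibition and lower numbers for stronger inhibition. Compound 1, `O=C1C(O)=C(O)OC12CCCC2`, reaches only the limit of the assay, > 4000000 nM, and that limit is the one at the limit of > 4000000 nM in this assay, at which 1 of the 3 values shown sits. Compound 2, `O=c1c(O)c(O)oc2ccc(O)cc12`, gives 1520000 nM in this assay. Compound 3, `O=C1C(O)=C(O)OC2CCCCC12`, gives 406000 nM in this assay, the lowest of the two numbers, and the gap to compound 2 lies beyond the scatter. Compound 4, `O=C1C(O)=C(O)OC2CCCC[C@H]12`, is the next compound in the series. Going from compound 3 to compound 4 the change is the two compounds have the same atoms and bonds; at least one stereo element is drawn with a configuration in one of them and without one in the other: 1 of 2 stereo elements differ; a stereocentre at a saturated ring carbon is drawn without a configuration in compound 3 and S in compound 4; the same atoms and bonds are kept, and only the drawn configuration at one saturated ring carbon differs. Among the compounds with values here, no step between two measured compounds in this assay is available to set against this change. With the stereocentre now drawn as S, a step of no more than the scatter, perhaps slightly toward stronger inhibition, is expected, so compound 4 is estimated at 300000 nM in this assay, within 150000 nM to 800000 nM, a change of a 1.4-fold lower number from compound 3 to compound 4 (0.13 log units; within the scatter).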

Compound 4, half-maximal inhibitory concentration: 492000 nM
For compound 4 the middle estimate is 1.6-fold (0.21 log units) below the measured one, within the range that was stated.
By their numbers in this assay, from the lowest: compounds 3 and 4 (each within the scatter of the next); then compound 2. At a limit, above all of these: compound 1.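

Within the data shown here, this is the first step in this assay between two compounds that differ in one place, and it reads a 1.2-fold higher number from compound 3 to compound 4 (0.08 log units; within the scatter). Drawing the stereocentre at the saturated ring carbon as S therefore gives a number that cannot be told apart from the one without a drawn configuration, so this change shows no measurable effect on inhibition. The step does not set two defined configurations against each other, and one fact limits what it can say about the stereocentre: the fact that one of compounds 3 and 4 is drawn with a defined configuration and the other without, at the place where they differ

The compounds shown leave open how the R configuration at that carbon would read in this assay. They also leave open whether a substituent on the saturated ring, such as an amine or a carboxylic acid, would move the number beyond the scatter.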